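The source may hold more compounds than are shown below. What is called first, only, known or untested is meant among the compounds shown, and "the series" means these compounds.

Compound 1 `Cc1cn2c(/C=N/NC(=N)N)c(-c3cccnc3)nc2s1` is one of three compounds that share a core and differ only at the edges. In a functional assay on ovarian cells (Homo sapiens) for antiproliferative activity (on this read-out lower numbers stand for stronger inhibition of growth and higher numbers for weaker inhibition of growth), compound 1 gives 36300 nM. Compound 2 `N=C(N)N/N=C/c1c(-c2cccnc2)nc2sc(Cl)cn12` gives 36300 nM, the same number at the digits given, so the step of no change at the digits printed from compound 1 to compound 2 (within the scatter) is no movement at all. Compound 3 `N=C(N)N/N=C/c1c(-c2ccncc2)nc2sc(Cl)cn12` gives 20900 nM, and the step of a 1.7-fold lower number from compound 2 to compound 3 (0.24 log units; within the scatter) stays inside the usual scatter of this assay, so the three numbers cannot be ranked against each other.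

Compound 4 `Cc1cn2c(/C=N/NC(=N)N)c(-c3ccccn3)nc2s1` arises from compound 1 by a single change: pyridin-2-yl in place of pyridin-3-yl on an aromatic carbon. Within the data shown here, the only measured step that touches the same group is the step from compound 2 to compound 3, where moving the ring nitrogen to another position left the number within the scatter. On that basis the step of a 1.1-fold lower number from compound 1 to compound 4 (0.04 log units; within the scatter) is expected to be small, without a clear direction. For compound 4 the estimate is therefore 33000 nM, with a likely range from 11000 nM to 100000 nM.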

Compound 4, concentration for total growth inhibition: 63100 nM
Estimate against measurement, compound 4: 1.9-fold (0.28 log units) below; measured number inside the range.
By their numbers in this assay, from the lowest: compounds 3, 1, 2 and 4 (each within the scatter of the next, the first and the last beyond it).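

In this assay, putting pyridin-2-yl in place of pyridin-3-yl gives a 1.7-fold higher number from compound 1 to compound 4 (0.24 log units; within the scatter) and so stays within the usual scatter of repeated measurements. Among these compounds, the earlier step between pyridin-3-yl and pyridin-4-yl was seen only on compounds with chloro on the shared core, whereas this one shows that moving the ring nitrogen also leaves the number within the scatter on a compound with methyl there. These two steps give no ranking of the pyridine attachments at this position, and nothing shown here offers an explanation for either of them.

Going by these compounds, it remains open whether pyridin-2-yl would also stay within the scatter on a compound with chloro in place of methyl. On these data alone, it is also open whether a phenyl ring, or a ring carrying an amine or a carboxylic acid, would take the number beyond the scatter at this position.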